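The compounds below may be only part of what the source reports. "The series", "measured", "known", "first", "only" and "open" are said of these compounds alone.

Of the compounds shown here, three sharing one core have been tested in a functional assay on Vero cells (Chlorocebus sabaeus) for cytotoxicity; a higher number here means that more compound is tolerated, a lower number that less compound is tolerated. Compound 3 `COC(=O)OCC(CO)CCn1cnc2cnc(N)nc21` gives in this assay a value recorded only as a limit of the method, > 500000 nM. Compound 2 `CCCOC(=O)OCC(CO)CCn1cnc2cnc(N)nc21` likewise reaches only a limit in this assay, > 500000 nM. Compound 1 `CC(C)CCOC(=O)OCC(CO)CCn1cnc2cnc(N)nc21` gives a number in this assay, 357000 nM. The measured steps run an at least 1.4-fold higher number from compound 1 to compound 2 (0.14 log units; that floor lies within the scatter) and an at least 1.4-fold higher number from compound 1 to compound 3 (0.14 log units; that floor lies within the scatter), while a step that the two limits leave unreadable from compound 2 to compound 3 because of the limit of > 500000 nM in this assay, at which 2 of the 3 values shown sit. Compound 3 therefore stands at a limit of this assay, as does one further value among the three.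

Compound 4 `CCCCOC(=O)OCC(CO)CCn1cnc2cnc(N)nc21` differs from compound 3 by propyl in place of hydrogen on a saturated chain carbon bound to an oxygen next to a carbonyl group. The entering propyl is longer than the ethyl that compound 2 carries on that same carbon and shorter than the isobutyl of compound 1 there. Both measured steps that start from compound 3 stay within the scatter or cannot be read, so no step beyond the scatter is expected in this assay for compound 4. Compound 4 is expected to give 450000 nM, within a range from 250000 nM to 800000 nM. The expected step of an at least 1.1-fold lower number from compound 3 to compound 4 (0.04 log units; that floor lies within the scatter) thus amounts to no change beyond the scatter, with a fair chance that only a limit is reported again.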

Compound 4, half-maximal cytotoxic concentration: > 500000 nM
Compound 4 gave a limit, no number; the forecaster's own chance of this, stated with the estimate: 55%; middle value at least 1.1-fold (0.04 log units) from the limit.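

Propyl in place of hydrogen on a saturated chain carbon bound to an oxygen next to a carbonyl group still gives no number in this assay. For compound 4 the record is only a limit, > 500000 nM. That leaves the steps reaching compound 4 from compound 3 and from compound 2 unreadable, because all of these compounds sit at one limit: the limit of > 500000 nM in this assay, at which 3 of the 4 values shown sit.

Within the data shown here, the only readable step comes from hydrogen in place of methyl on a saturated chain carbon bound to two saturated chain carbons, and it is an at least 1.4-fold higher number from compound 1 to compound 4 (0.14 log units; that floor lies within the scatter). This floor alone therefore shows no difference beyond the scatter for that change, even though the butyl of compound 4 and the isopentyl-type chain of compound 1 differ by only that one methyl.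

As far as these compounds go, the true size of that step stays open, and so does any order among compound 2, compound 3 and compound 4 in this assay. From the compounds shown here alone, it also remains open whether a longer chain, or an amine or a carboxylic acid carried on this carbon, would give a number in this assay and how that number would compare with compound 1.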